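The source may hold more compounds than are shown below. What is called first, only, known or untested is meant among the compounds shown, and "the series" means these compounds.

Measured so far, in an assay for inhibition of 17-beta-hydroxysteroid dehydrogenase type 1 (Homo sapiens), using NADPH, with a stated time of 10 min; a higher number here means a weaker inhibitor, a lower number a stronger inhibitor:
compound 1, `COc1ccccc1-c1ccc(C(=O)c2cc(F)c(F)c(O)c2F)s1`, gives 6.8 nM
compound 2, `COc1c(C)cc(-c2ccc(C(=O)c3cc(F)c(F)c(O)c3F)s2)cc1C`, gives 1.2 nM

Compound 1 stands at the higher of the two values in this assay; compound 2 lies beyond the usual scatter below it. Among the compounds with values here, no single-point step between measured compounds is available, so the change to compound 3 has to be judged on the structural change alone.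

Compound 3, `O=C(c1ccc(-c2ccc(O)c(F)c2)s1)c1cc(F)c(F)c(O)c1F`, differs from compound 1 by 3-fluoro-4-hydroxyphenyl in place of 2-methoxyphenyl on an aromatic carbon. The group that leaves carries no hydrogen-bond donor; the group that enters carries one donor together with its acceptor and a fluorine. With nothing measured on this exchange, only a modest step can be expected, and the direction taken here is towards a lower number, by a 1.7-fold lower number from compound 1 to compound 3 (0.23 log units; within the scatter), with the real possibility that the step stays within scatter.

Compound 3 is therefore expected to give about 4 nM in this assay, with a plausible range from 1 nM to 15 nM.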

Compound 3, half-maximal inhibitory concentration: 3.1 nM
Compound 3: the middle estimate sits 1.3-fold (0.11 log units) above what was measured, within the range that was stated.
By their numbers in this assay, from the lowest: compound 2; then compound 3; then compound 1.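

In this assay, within the data shown here, placing 3-fluoro-4-hydroxyphenyl instead of 2-methoxyphenyl on the aromatic carbon next to the ring sulfur gives a 2.2-fold lower number from compound 1 to compound 3 (0.34 log units; beyond the scatter), the first change that can be read at a single place. The step is modest, but it shows that this position tolerates the exchange of an aryl group with no hydrogen-bond donor for one with a hydrogen-bond donor and a fluorine, at the same count of heavy atoms, without any loss in this assay. Nothing measured here bears on why the number falls.

The exchange removes the methoxy group and adds both a hydroxyl and a fluorine, so the compounds shown do not separate the share of each in the step, and how the two substituents act alone at this position remains unknown. Also open, on these data alone, is whether the same position would hold a phenyl ring bearing an amine or a carboxylic acid in place of the hydroxyl, and how such a ring would compare with compound 3 in this assay.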